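Cytotoxicity notes: chloro added to the aryl of compound 1

The source may hold more compounds than are shown below. What is called first, only, known or untested is meant among the compounds shown, and "the series" means these compounds.

Measured compounds:
compound 1, `Fc1ccc(-n2cc(COc3ccccc3-c3nc4ccccc4s3)nn2)cc1`: 33300 nM
compound 2, `COc1cc(-c2cc(COc3ccccc3-c3nc4ccccc4s3)on2)cc(OC)c1OC`: 42900 nM
compound 3, `FC(F)(F)Oc1ccc(-c2cc(COc3ccccc3-c3nc4ccccc4s3)on2)cc1`: 43900 nM

All three have been run in an ADME assay on MCF-10A cells (Homo sapiens) for cytotoxicity, read by MTT assay, with a stated time of 24 h; a higher number here means a weaker inhibitor, a lower number a stronger inhibitor. Compound 1 returns the lowest of the three numbers, but compound 2 and compound 3 each lie within the scatter of it, so no order among the three can be read from these figures; they read as one level of weak cytotoxicity. Among the compounds with values here, no pair of measured compounds differs in a single place, so no step can be taken from the measured set itself.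

Compound 4, `Fc1ccc(-n2cc(COc3ccccc3-c3nc4ccccc4s3)nn2)cc1Cl`, has not yet been run in this assay. Against compound 1 the change is chloro in place of hydrogen on an aromatic carbon. Within the data shown here, with no measured step to lean on and all three measured numbers sitting at the same level, the step from compound 1 to compound 4 is expected to be small, a 1.2-fold lower number from compound 1 to compound 4 (0.08 log units; within the scatter), with no direction beyond the scatter. On that basis compound 4 is estimated at 28000 nM in this assay, in a range from 11000 nM to 70000 nM.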

Compound 4, half-maximal inhibitory concentration: 26300 nM
Compound 4: middle estimate off by 1.1-fold (0.03 log units), on the high side; the measured number falls inside the stated range.
By their numbers in this assay, from the lowest: compounds 4, 1, 2 and 3 (each within the scatter of the next).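

Within the data shown here, the step on adding chloro in place of hydrogen, on an aromatic carbon ortho to a fluoro group, is a 1.3-fold lower number from compound 1 to compound 4 (0.10 log units; within the scatter) in this assay, the first comparison in this set that differs in one place. The 4-fluorophenyl to 3-chloro-4-fluorophenyl change therefore leaves both compounds at one level, and no direction can be assigned to it. At this position, one added chlorine atom does not take the compound away from the level shared by the other measured compounds, and no accompanying measurement offers an explanation for this.

This single substituent at a single position says nothing about how an amine, a carboxylic acid or a longer alkyl chain at the same carbon would read. As far as these compounds go, it also remains open whether chloro would give a similar result on the aryl groups of compound 2 or compound 3.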